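The compounds below may be only part of what the source reports. "The series", "measured", "known", "first", "only" and "open" are said of these compounds alone.

Compound 1, `O=C(/C=C/c1cn(-c2ccccc2)nc1-c1ccsc1)c1ccccc1`, in a functional assay on Huh-7 cells (Homo sapiens) for inhibition, read by sulforhodamine B assay, with a stated time of 72 h; on this read-out lower numbers stand for stronger inhibition and higher numbers for weaker inhibition: 4700 nM
Compound 2, `O=C(/C=C/c1cn(-c2ccccc2)nc1-c1cccnc1)c1ccsc1`, in this assay: 1700 nM
Compound 3, `O=C(/C=C/c1cn(-c2ccccc2)nc1-c1cccnc1)c1ccccc1`, in this assay: 2300 nM

Among these three numbers compound 3 stands second highest. Its nearest neighbour is compound 2, whose number lies within the scatter of that of compound 3, so no order between the two can be read; its furthest is compound 1, and the step of a 2.0-fold lower number from compound 1 to compound 3 (0.31 log units; beyond the scatter) lies beyond the scatter.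

Compound 4, `COc1ccc(C(=O)/C=C/c2cn(-c3ccccc3)nc2-c2cccnc2)c(OC)c1`, is not yet measured. It differs from compound 3 at the carbonyl carbon: 2,4-dimethoxyphenyl in place of phenyl on a carbonyl carbon. Going by the values given here, the one measured step at the same place is a 1.4-fold higher number from compound 2 to compound 3 (0.13 log units; within the scatter), which lies within the scatter. The other measured step concerns the aromatic carbon of the shared core and does not bear on this change. Nothing measured here speaks to methoxy groups. The expectation for compound 4 in this assay is therefore no step beyond the scatter, with wide uncertainty. Compound 4 is estimated at 2000 nM, between 600 nM and 7000 nM. This estimate means an expected step of a 1.2-fold lower number from compound 3 to compound 4 (0.06 log units; within the scatter).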

Compound 4, half-maximal inhibitory concentration: 2400 nM
Compound 4: middle estimate off by 1.2-fold (0.08 log units), on the low side, within the range that was stated.
By their numbers in this assay, from the lowest: compounds 2, 3, 4 and 1 (each within the scatter of the next, the first and the last beyond it).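

In this assay, the carbonyl carbon now carries a substituted ring as well as plain phenyl and thiophen-3-yl. Putting 2,4-dimethoxyphenyl in place of phenyl gives a 1.0-fold higher number from compound 3 to compound 4 (0.02 log units; within the scatter), and putting it in place of thiophen-3-yl gives a 1.4-fold higher number from compound 2 to compound 4 (0.15 log units; within the scatter), so the larger group, with 10 heavy atoms and 2 hydrogen-bond acceptors, leaves the number within the scatter across all three groups at this position. Nothing available accounts for this result.

On these data alone, it remains open whether a different kind of group on the carbonyl carbon, such as an amine or a carboxylic acid, would move the number, and whether a single methoxy group would behave like the pair. The step from thiophen-3-yl to pyridin-3-yl on the aromatic carbon is also known only with phenyl on the carbonyl carbon, not with 2,4-dimethoxyphenyl.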